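The source may hold more compounds than are shown below. What is called first, only, known or untested is meant among the compounds shown, and "the series" means these compounds.

In a functional assay on MCF7 cells (Homo sapiens) for cytotoxicity, read by fluorescence, with a stated time of 72 h (on this read-out lower numbers stand for stronger inhibition and higher numbers for weaker inhibition), three compounds sharing one core have been measured, differing only in the group on an aromatic carbon between two ring nitrogen atoms. With methylsulfonyl there, compound 1 (`CC(C)c1n[nH]c2c(NCc3ccc(-c4ccccn4)cc3)nc(S(C)(=O)=O)nc12`) gives 460 nM. With (2-hydroxy-2-methylpropyl)amino, compound 2 (`CC(C)c1n[nH]c2c(NCc3ccc(-c4ccccn4)cc3)nc(NCC(C)(C)O)nc12`) gives 24 nM, and with piperazin-1-yl, compound 3 (`CC(C)c1n[nH]c2c(NCc3ccc(-c4ccccn4)cc3)nc(N3CCNCC3)nc12`) gives 21 nM. Replacing methylsulfonyl goes with large steps: a 19-fold lower number from compound 1 to compound 2 (1.28 log units; beyond the scatter) and a 22-fold lower number from compound 1 to compound 3 (1.34 log units; beyond the scatter). The remaining comparison shows no real gap, only a 1.1-fold lower number from compound 2 to compound 3 (0.06 log units; within the scatter). Compound 3 therefore shares the low end of the numbers seen so far.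

Compound 4 (`CC(C)c1n[nH]c2c(NCc3ccc(-c4ccccn4)cc3)nc(N[C@H]3CC[C@H](N)CC3)nc12`) carries (4-aminocyclohexyl)amino in place of piperazin-1-yl on that aromatic carbon: (4-aminocyclohexyl)amino in place of piperazin-1-yl on an aromatic carbon. The two large steps both start from methylsulfonyl, which plays no part in this change, so they set no size for it. The nearest guide is a 1.1-fold lower number from compound 2 to compound 3 (0.06 log units; within the scatter), an exchange of one nitrogen-attached group for another. Among the measured compounds shown here, no measured compound tests a ring of carbon only at this position, so some uncertainty remains. In this assay, no step beyond the scatter is expected, and no direction can be favoured. The expected step is a 1.1-fold lower number from compound 3 to compound 4 (0.02 log units; within the scatter). For compound 4 the estimated value is 20 nM, with an expected range of 7 nM to 60 nM.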

Compound 4, half-maximal inhibitory concentration: 474 nM
Beside the measured number, compound 4's estimate is 24-fold (1.37 log units) below it; measured number outside the range, above it.
By their numbers in this assay, from the lowest: compounds 3 and 2 (each within the scatter of the next); then compounds 1 and 4 (each within the scatter of the next).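

In this assay, compounds 2 and 3 left the impression that any group attached through nitrogen at this position gives a low number, but compound 4 breaks that impression, with a 23-fold higher number from compound 3 to compound 4 (1.35 log units; beyond the scatter) and a 20-fold higher number from compound 2 to compound 4 (1.30 log units; beyond the scatter) as well. Attachment through nitrogen is therefore not enough on its own: compound 4 has it too, yet replacing methylsulfonyl with (4-aminocyclohexyl)amino leaves the number within the scatter, at a 1.0-fold higher number from compound 1 to compound 4 (0.01 log units; within the scatter). This is unlike the large drops seen for compounds 2 and 3. What the nitrogen carries clearly matters here, and the change from piperazin-1-yl alters several things at once, putting a ring of carbon only in place of a ring with two hetero atoms and adding two defined stereocentres.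

A cyclohexylamino group without the second amine, or a piperidin-1-yl group, would help separate the part played by the carbon ring from the part played by that amine. Nothing available here explains why the number rises so sharply, so which of these differences counts remains unsettled.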